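A Bromo Group Added to the Triazole Phenyl of Compound 3

This account rests on a few compounds, and the source may have more. Where it says the series, first, only, none or still open, it means among the compounds named here.

Compound 1, `C=C1C[C@]23C[C@@]1(O)CC[C@H]2c1ccc(O)c(C)c1[C@@H]3Cn1cc(-c2ccccn2)nn1`: > 20000 nM
Compound 2, `C=C1C(=O)[C@]23C[C@@]1(O)CC[C@H]2c1ccc(OS(=O)(=O)c2ccc(C)cc2)c(C)c1[C@@H]3Cn1cc(-c2ccc(Cl)cc2)nn1`: 6180 nM
Compound 3, `C=C1C(=O)[C@]23C[C@@]1(O)CC[C@H]2c1ccc(O)c(C)c1[C@@H]3Cn1cc(-c2ccccc2)nn1`: 1320 nM

Of the compounds shown here, three sharing one core have been tested in a functional assay on SMMC-7721 cells (Homo sapiens) for cytotoxicity, read by MTT assay, with a stated time of 4 days; a lower number here means a stronger inhibitor, a higher number a weaker inhibitor. For compound 1 the result is a limit of the assay, (the limit of > 20000 nM in this assay, at which 1 of the 3 values shown sits), and not a number. Of the two numbers, compound 3 has the lowest in this assay; its nearest neighbour is compound 2, whose number is higher by a margin beyond the scatter. For the measured compounds named here, compound 2 and compound 3 differ in more than one place, so their two values say only that compound 3 gave the stronger result.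

Compound 4, `C=C1C(=O)[C@]23C[C@@]1(O)CC[C@H]2c1ccc(O)c(C)c1[C@@H]3Cn1cc(-c2ccc(Br)cc2)nn1`, has not yet been measured. It differs from compound 3 by bromo in place of hydrogen on an aromatic carbon; read one bond further out, phenyl becomes 4-bromophenyl. Going by the values given here, no pair already measured shows this change on its own, so there is no measured step to lean on. A small step is expected from compound 3 to compound 4 in this assay, a 1.2-fold lower number from compound 3 to compound 4 (0.08 log units; within the scatter), in either direction and not clearly beyond the scatter. Compound 4 is therefore estimated at 1100 nM, between 400 nM and 3300 nM.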

Compound 4, half-maximal inhibitory concentration: 1300 nM
Estimate against measurement, compound 4: 1.2-fold (0.07 log units) below; low and high end bracket the measured number.
By their numbers in this assay, from the lowest: compounds 4 and 3 (each within the scatter of the next); then compound 2. At a limit, above all of these: compound 1.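

In this assay, for the compounds shown here, the change of hydrogen to bromo on an aromatic carbon, para to a large group, is seen on its own for the first time and reads as a 1.0-fold lower number from compound 3 to compound 4 (0.01 log units; within the scatter) within the shared core. Compound 1 and compound 2 each differ from compound 3 in more than one place, so neither could show this, whereas the new pair shows that phenyl and 4-bromophenyl give values that cannot be told apart at this place in this assay. Nothing among the data shown accounts for why the value stays where it does.

The compounds shown leave open whether a group of another kind at this same place, such as an amine, a carboxylic acid or a methoxy group, would give a step beyond the scatter, as bromo is the only replacement for hydrogen shown there. They also leave open whether the bromo step would read the same on a compound that carries a different group in place of the hydroxy group on the aromatic ring of the core, such as an acetate ester.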